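The source may report more compounds than this note shows. Statements on the series, on what has been measured and on what is new or still open speak of the compounds shown alone.

Measured compounds:
Compound 1 `Cc1cccnc1-c1ccc(C(=O)Nc2ccc(C(C)C)cc2)cc1`, value in a functional assay for antagonist activity at transient receptor potential cation channel subfamily V member 1 (Rattus norvegicus) (on this read-out higher numbers stand for weaker inhibition and lower numbers for stronger inhibition), 43 nM
Compound 2 `CC(C)(C)c1ccc(NC(=O)c2ccc(-c3ncccc3C#N)cc2)cc1`, value in this assay 13 nM

Of the compounds shown here, two have been measured in this assay. Compound 1 `Cc1cccnc1-c1ccc(C(=O)Nc2ccc(C(C)C)cc2)cc1` gives 43 nM in this assay, while compound 2 `CC(C)(C)c1ccc(NC(=O)c2ccc(-c3ncccc3C#N)cc2)cc1` gives 13 nM. Compound 2 thus holds the lowest of the two numbers; the nearest is compound 1, whose number is higher by a margin that lies beyond the usual scatter of such measurements.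

The next compound, compound 3 `CC(C)(C)c1ccc(NC(=O)c2ccc(-c3ncccc3C(=O)O)cc2)cc1`, has not yet been measured in this assay. It differs from compound 2 in one place: carboxy in place of cyano on an aromatic carbon, that is, a carboxy in place of cyano on an aromatic carbon. Within the data shown here, no measured pair shows this exchange, so there is no step to rest on, and what follows is an expectation only.

For compound 3, the step from compound 2 is expected to go toward a higher number, about a 12-fold higher number from compound 2 to compound 3 (1.06 log units; beyond the scatter), which is more than the scatter alone would account for. Compound 3 is therefore estimated to give about 150 nM in this assay, with a likely range from 40 nM to 800 nM.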

Compound 3, half-maximal inhibitory concentration: 560 nM
Compound 3: middle estimate off by 3.7-fold (0.57 log units), on the low side; low and high end bracket the measured number.
By their numbers in this assay, from the lowest: compound 2; then compound 1; then compound 3.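

In this assay, the exchange of 3-cyanopyridin-2-yl for 3-carboxypyridin-2-yl gives a 43-fold higher number from compound 2 to compound 3 (1.63 log units; beyond the scatter), so this position, on an aromatic carbon two atoms from the ring nitrogen, clearly does not tolerate every group equally. The earlier compounds shown here could not show this: compound 1 and compound 2 differ in more than one place, and no step at this position could be read from them. The exchange replaces a group with 2 heavy atoms and no hydrogen-bond donor by one with 3 heavy atoms and 1 hydrogen-bond donor, but no measurement at hand bears on which of these differences, if any, accounts for the step.

The compounds shown leave open whether a methyl ester, a primary carboxamide or a hydroxymethyl group at this position would give a number closer to that of compound 2 or to that of compound 3. They also leave open whether the same exchange would have a step of similar size with the isopropyl group of compound 1 in place of the tert-butyl group of compound 2.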